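The source may report more compounds than this note shows. Statements on the series, on what has been measured and on what is new or still open speak of the compounds shown alone.

Compounds with measurements in an assay on HL-60 cells for agonist activity at vitamin D3 receptor (Homo sapiens), read by microscopy, with a stated time of 96 h; a lower number here means that less compound is needed, a higher number that more compound is needed for the effect:
compound 1 `CCOC(=O)CN(C)C(=O)c1ccc(C(CC)(CC)c2ccc(OCC(=O)C(C)(C)C)c(C)c2)n1CC` — > 50000 nM
compound 2 `CCn1c(C(=O)NCCN)ccc1C(CC)(CC)c1ccc(OCC(=O)C(C)(C)C)c(C)c1` — 120 nM
compound 3 `CC[C@@H](C)[C@H](NC(=O)c1ccc(C(CC)(CC)c2ccc(OCC(O)C(C)(C)C)c(C)c2)n1CC)C(=O)OC` — 26 nM

The compounds share one core and differ at the amide attached to it. Compound 1 gives only a limit of the assay, > 50000 nM, so its true position among the three is not fixed by a number (the limit of > 50000 nM in this assay, at which 1 of the 3 values shown sits). Compound 2 gives 120 nM, and compound 3, which carries a secondary amide and also a different side chain, gives 26 nM.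

Compound 4 `CCOc1ccc(NC(=O)c2ccc(C(CC)(CC)c3ccc(OCC(=O)C(C)(C)C)c(C)c3)n2CC)cc1` has not yet been measured. It differs from compound 1 in this way: (4-ethoxyphenyl)amino in place of ((ethoxycarbonyl)methyl)(methyl)amino on a carbonyl carbon. Among the measured compounds shown here, the one measured step that bears on this is an at least 410-fold lower number from compound 1 to compound 2 (2.61 log units; beyond the scatter), where exchanging the tertiary amide substituent of compound 1 for a secondary amide brought a very large lower number. Compound 4 likewise replaces the tertiary amide with a secondary one, so a large step downward, beyond the scatter, is expected, an at least 120-fold lower number from compound 1 to compound 4 (2.09 log units; beyond the scatter), although a substituted aromatic amine rather than a small basic chain enters. Compound 4 is therefore estimated at 400 nM, within a range of 40 nM to 5000 nM.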

Compound 4, half-maximal effective concentration: > 50000 nM
Compound 4: a limit, no number; the forecaster's own chance of this, stated with the estimate: 20%; middle value at least 120-fold (2.09 log units) from the limit.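

In this assay compound 4 gives only a limit of the assay, > 50000 nM. Putting 4-ethoxyphenyl in place of 2-aminoethyl on the amide-type nitrogen gives an at least 410-fold higher number from compound 2 to compound 4 (2.61 log units; beyond the scatter), so at this position a secondary amide by itself does not secure the low number of compound 2; the group on the amide-type nitrogen also matters. Compound 1 and compound 4 both give limits, and the step between them cannot be read: the limit of > 50000 nM in this assay, at which 2 of the 4 values shown sit.

The compounds shown leave open whether the amine at the end of the 2-aminoethyl chain of compound 2 is what counts, or the chain itself. They also do not tell how a longer chain ending in an amine, or a carboxylic acid at the end of that chain, would read.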